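Cytotoxicity notes: aryl swap from compound 3 to compound 4

A few compounds are considered here, and "the series" means these few. Any claim that something is new, unique, unknown or untested is made for them only; others in the source may bear on it.

The series shares one core carrying a hydrazone aryl group. Compound 1 `O=C(COc1cccc2ccccc12)N/N=C/c1ccc(Cl)cc1` gives 100 ug/mL in an ADME assay on HEL cells (Homo sapiens) for cytotoxicity; a higher number here means that more compound is tolerated, a lower number that less compound is tolerated. Compound 2 `O=C(COc1cccc2ccccc12)N/N=C/c1ccc(O)cc1` gives 20 ug/mL in this assay. Compound 3 `O=C(COc1cccc2ccccc12)N/N=C/c1cccc(Br)c1` gives 100 ug/mL in this assay.

Compound 3 stands level with compound 1, no change at the digits printed from compound 1 to compound 3 (within the scatter), and both sit above compound 2, a 5.0-fold higher number from compound 2 to compound 3 (0.70 log units; beyond the scatter); the only move beyond the scatter seen so far is a 5.0-fold lower number from compound 1 to compound 2 (0.70 log units; beyond the scatter).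

The next member is compound 4 `Cc1ccc(/C=N/NC(=O)COc2cccc3ccccc23)cc1`. Relative to compound 3 the change is 4-methylphenyl in place of 3-bromophenyl on a carbon with a double bond to nitrogen.

Going by the values given here, no measured step swaps a halogen for a methyl. Among the compounds with values here, the nearest guide is the halogen-to-halogen step, no change at the digits printed from compound 1 to compound 3 (within the scatter), which moved nothing; the one step that did move, a 5.0-fold lower number from compound 1 to compound 2 (0.70 log units; beyond the scatter), brought in a hydroxy group, which compound 4 lacks. The expectation is therefore no step beyond the scatter, no change at the digits printed from compound 3 to compound 4 (within the scatter). Compound 4 is estimated at 100 ug/mL, with a range from 50 ug/mL to 200 ug/mL.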

Compound 4, minimum cytotoxic concentration: 20 ug/mL
Estimate against measurement, compound 4: 5.0-fold (0.70 log units) above, outside the stated range (below it).
By their numbers in this assay, from the lowest: compounds 2 and 4 (each within the scatter of the next); then compounds 1 and 3 (each within the scatter of the next).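

In this assay, the aryl group on a carbon with a double bond to nitrogen proves sensitive even without a hydroxy group: a 5.0-fold lower number from compound 3 to compound 4 (0.70 log units; beyond the scatter), although the hydrogen-bond donor and acceptor counts of the leaving and entering groups are the same. With the substituent position held, the result is the same: a 5.0-fold lower number from compound 1 to compound 4 (0.70 log units; beyond the scatter), whereas no change at the digits printed from compound 2 to compound 4 (within the scatter), so methyl and hydroxy read alike here and both differ from chloro. Nothing measured in the series accounts for this shift.

Among the compounds shown, only the halogen-bearing compound 1 and compound 3 hold the higher level, and two examples cannot show whether a halogen is required for it. Where an amine or a methoxy group on the same aromatic carbon would fall remains open.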